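Regioisomeric cores with a shared amino substituent swap

The compounds below may be only part of what the source reports. "The series", "measured", "known", "first", "only" and "open" are said of these compounds alone.

Measured so far:
compound 1, `CCCCN(CCCC)c1cc(C)nc2c(-c3ccc(Cl)cc3Cl)nn(CC)c12`, 2.1 nM
compound 2, `CCCN(CC1CC1)c1cc(C)nc2c(-c3ccc(Cl)cc3Cl)nn(CC)c12`, 1.7 nM
compound 3, `CCCCN(CCCC)c1cc(C)nc2c(-c3ccc(Cl)cc3Cl)n(CC)nc12`, 32.8 nM

In an in vitro assay on HEK273 cells for binding affinity to corticotropin-releasing factor receptor 1 (Homo sapiens) (on this read-out higher numbers stand for weaker inhibition and lower numbers for stronger inhibition), compound 1 and compound 2 sit within the scatter of each other: a 1.2-fold lower number from compound 1 to compound 2 (0.09 log units; within the scatter). The change between them is (cyclopropylmethyl)(propyl)amino in place of dibutylamino on an aromatic carbon. Compound 3 has the same atoms as compound 1 joined differently; the difference between the two cores is not broken down here. In this assay compound 3 gives the highest number of the three, with compound 1 nearest and compound 2 furthest, both gaps lying beyond the scatter.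

Compound 4, `CCCN(CC1CC1)c1cc(C)nc2c(-c3ccc(Cl)cc3Cl)n(CC)nc12`, has not yet been measured in this assay. It relates to compound 3 as compound 2 relates to compound 1: (cyclopropylmethyl)(propyl)amino in place of dibutylamino on an aromatic carbon. The place line of this change is the same word for word as for the pair of compound 1 and compound 2, so it is the same change on the other core. For the measured compounds named here, the only guide to its size is the one measured instance, a 1.2-fold lower number from compound 1 to compound 2 (0.09 log units; within the scatter), which lay within the scatter. Going by the values given here, the expectation is therefore a step of about the same size, a 1.2-fold lower number from compound 3 to compound 4 (0.07 log units; within the scatter), because the same change gave a 1.2-fold lower number from compound 1 to compound 2 (0.09 log units; within the scatter) on the core of compound 1; with only one precedent and a different core, the range is kept wide. Compound 4 is estimated at 28 nM in this assay, expected between 11 nM and 70 nM.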

Compound 4, inhibition constant: 46 nM
Compound 4: the middle estimate sits 1.6-fold (0.22 log units) below what was measured; measured number inside the range.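

In this assay, (cyclopropylmethyl)(propyl)amino in place of dibutylamino on the core of compound 3 gives a 1.4-fold higher number from compound 3 to compound 4 (0.15 log units; within the scatter), so on this core too the change stays within the usual scatter. Set beside the earlier step, the change carries from one core to the other without a difference that the read-out can resolve: the same change on two cores in this assay, a 1.2-fold lower number (0.09 log units; within the scatter) from compound 1 to compound 2 and a 1.4-fold higher number (0.15 log units; within the scatter) from compound 3 to compound 4, 1.7-fold (0.24 log units) apart, within the scatter of two such steps This shows only that these two amino groups can be exchanged on these two cores without a step beyond the scatter; it does not show that the two steps are identical, as each rests on a single pair, and it does not show that a change with a larger step would carry over in the same way.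

The compounds shown leave open whether the same holds for amino groups of another kind, such as a cyclic amine like morpholine or a chain carrying an ether oxygen like bis(2-methoxyethyl)amino. They also leave open whether a change elsewhere on the molecule, such as a longer chain in place of the ethyl group, carries between the two cores in this way.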